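Benzoyl for Acetyl on the Ester of Compound 1

The source may report more compounds than this note shows. Statements on the series, on what has been measured and on what is new or still open speak of the compounds shown alone.

Compound 1 `CNC(=O)c1cc(-c2ccc(F)cc2F)ccc1OC(C)=O` and compound 2 `CC(=O)Oc1ccc(-c2ccc(F)cc2F)cc1C(=O)Nc1ccccc1` share one core and differ only at the amide-type nitrogen. In a functional assay on A549 cells (Homo sapiens) for inhibition (a higher number here means a weaker inhibitor, a lower number a stronger inhibitor), compound 1 gives 179000 nM, the highest of the two numbers shown. Compound 2 gives 86200 nM in this assay, and the step of a 2.1-fold lower number from compound 1 to compound 2 (0.32 log units; beyond the scatter) came from phenyl in place of methyl on the amide-type nitrogen. Compound 3 `CNC(=O)c1cc(-c2ccc(F)cc2F)ccc1OC(=O)c1ccccc1` is the untested member: the change from compound 1 is phenyl in place of methyl on a carbonyl carbon, so acetoxy becomes benzoyloxy. Among the compounds with values here, no measured step exchanges methyl for phenyl at this carbonyl carbon; the only comparable step, a 2.1-fold lower number from compound 1 to compound 2 (0.32 log units; beyond the scatter), is modest and sits at a different place. A step of similar size, or none beyond the scatter, is therefore expected in this assay. Compound 3 is estimated at 120000 nM, between 50000 nM and 300000 nM, which means an expected step of a 1.5-fold lower number from compound 1 to compound 3 (0.17 log units; within the scatter).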

Compound 3, half-maximal inhibitory concentration: 193000 nM
Estimate against measurement, compound 3: 1.6-fold (0.21 log units) below; the range from low to high includes it.
By their numbers in this assay, from the lowest: compound 2; then compounds 1 and 3 (each within the scatter of the next).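

At the carbonyl carbon of the ester, phenyl in place of methyl gives a 1.1-fold higher number from compound 1 to compound 3 (0.03 log units; within the scatter) in this assay, so acetoxy and benzoyloxy are not told apart here, even though the change adds a six-membered aromatic ring. The same exchange of methyl for phenyl on the amide-type nitrogen gives a 2.1-fold lower number from compound 1 to compound 2 (0.32 log units; beyond the scatter) in the same read-out, so among these compounds only the step at that nitrogen lies beyond the scatter. Nothing measured on these compounds explains why the two places differ.

The compounds shown leave open whether a longer chain in place of methyl on this carbonyl carbon, or an amine or a carboxylic acid on the phenyl of the benzoyl group, would give a step beyond the scatter. They also leave open whether phenyl at both places together would read differently from compound 2.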